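Phenyl for pyridin-2-yl on a ring amine nitrogen

This account rests on a few compounds, and the source may have more. Where it says the series, first, only, none or still open, it means among the compounds named here.

In a functional assay on SK-MEL-5 cells (Homo sapiens) for inhibition, read by MTT assay, with a stated time of 48 h (on this read-out higher numbers stand for weaker inhibition and lower numbers for stronger inhibition), compound 1 `COc1ccccc1OCCNCC(O)COc1ccc2ccccc2c1` gives 18500 nM while compound 2 `COc1ccccc1OCCNCC(O)COc1ccc(-c2ccccc2)cc1` gives 5860 nM and compound 3 `OC(COc1ccc(-c2ccccc2)cc1)CN1CCN(c2ccccn2)CC1` gives 21200 nM as its result. Compound 3 thus sits level with compound 1 within the usual scatter of repeat measurements, and its number is clearly higher than that of compound 2, which means weaker inhibition.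

Compound 4 `OC(COc1ccc(-c2ccccc2)cc1)CN1CCN(c2ccccc2)CC1` has not been measured yet. It differs from compound 3 in a single place, with phenyl in place of pyridin-2-yl on an amine nitrogen in a ring. Among the measured compounds shown here, no two measured compounds differ in one place only, so the data offer no direct precedent for this swap. In this assay a step no larger than the scatter is expected, with a slight lean towards stronger inhibition. The expected size is a 1.4-fold lower number from compound 3 to compound 4 (0.15 log units; within the scatter) as a best estimate. Compound 4 is expected at 15000 nM with an estimated range of 7000 nM to 30000 nM for its measurement.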

Compound 4, half-maximal inhibitory concentration: 12200 nM
For compound 4 the middle estimate is 1.2-fold (0.09 log units) above the measured one; the measured number falls inside the stated range.
By their numbers in this assay, from the lowest: compound 2; then compounds 4, 1 and 3 (each within the scatter of the next).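

In this assay, among the compounds shown here, the swap gives a 1.7-fold lower number from compound 3 to compound 4 (0.24 log units; within the scatter) and so provides the first comparison in this set between two compounds that differ in one place only. Pyridin-2-yl and phenyl have the same number of heavy atoms and differ in one ring atom, with the ring nitrogen and its hydrogen-bond acceptor absent from phenyl, yet compound 3 and compound 4 read as level on this amine nitrogen in a ring. The data shown offer no measured basis for explaining this result.

On these data alone, it remains open whether a larger change at this nitrogen, such as benzyl or acetyl in place of the aromatic ring, would shift the number beyond the scatter. As far as these compounds go, it is also open whether an amine or a carboxylic acid on the phenyl ring would do so.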